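Swapping a Hydroxyl for Fluorine on the Benzyl Arm

This account rests on a few compounds, and the source may have more. Where it says the series, first, only, none or still open, it means among the compounds named here.

Compound 1, `O=C1N[C@H]2[C@H](CS[C@H]2CCCCCc2cn(Cc3ccccc3O)nn2)N1`, was tested in an assay on isolated protein for inhibition of biotin--protein ligase (Homo sapiens), read by scintillation counting, with a stated time of 10 min; on this read-out higher numbers stand for weaker inhibition and lower numbers for stronger inhibition. In this assay compound 1 gives > 16000 nM, which is a limit of the assay and not a number. Two measured compounds differ from it in one place each. Compound 2, `COc1ccccc1Cn1cc(CCCCC[C@@H]2SC[C@@H]3NC(=O)N[C@@H]32)nn1`, carries methyl in place of hydrogen on an oxygen on an aromatic ring, and in this assay compound 2 gives > 16000 nM, again only a limit. Compound 3, `O=C1N[C@H]2[C@H](CS[C@H]2CCCCCc2cn(Cc3ccc(C(F)(F)F)cc3)nn2)N1`, bears 4-(trifluoromethyl)phenyl in place of 2-hydroxyphenyl on a saturated chain carbon bound to an aromatic nitrogen, and in this assay compound 3 gives > 16000 nM, likewise a limit. The steps a step that the two limits leave unreadable from compound 1 to compound 2, a step that the two limits leave unreadable from compound 1 to compound 3 and a step that the two limits leave unreadable from compound 2 to compound 3 cannot be sized, because of the limit of > 16000 nM in this assay, at which 3 of the 3 values shown sit. Compound 4, `O=C1N[C@H]2[C@H](CS[C@H]2CCCCCc2cn(Cc3cccc(F)c3)nn2)N1`, differs from compound 1 by 3-fluorophenyl in place of 2-hydroxyphenyl on a saturated chain carbon bound to an aromatic nitrogen. Going by the values given here, no measured step with a readable size bears on this change. Compound 4 is expected to sit once more at the limit, a step that the limit leaves unreadable from compound 1 to compound 4. The estimate for compound 4 is 30000 nM, between 8000 nM and 120000 nM.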

Compound 4, inhibition constant: > 16000 nM
Compound 4: a limit, no number; the forecaster's own chance of this, stated with the estimate: 85%; the middle value is on the limit's open side.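

No step can be read from compound 4 to compound 1, compound 2 or compound 3, since all four compounds end at a limit and not at a number: the limit of > 16000 nM in this assay, at which 4 of the 4 values shown sit. The compounds shown leave open whether these different benzyl arms differ at all in this assay.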